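Swapping cyclopentyl for pyrimidin-4-yl on the amide carbonyl

A few compounds are considered here, and "the series" means these few. Any claim that something is new, unique, unknown or untested is made for them only; others in the source may bear on it.

Of the compounds shown here, three sharing one core have been measured in an assay for inhibition of inositol hexakisphosphate kinase 2 (Homo sapiens), read by colorimetric assay, coupled enzyme assay and malachite green, with a stated time of 120 min, in the presence of a further agent that is not named here; a lower number here means a stronger inhibitor, a higher number a weaker inhibitor. Compound 1 `O=C(O)c1ccc2noc(-c3ccc(Oc4ncc(Cl)cc4Cl)cc3)c2c1` gives 650 nM, compound 2 `CC(C)C(=O)Nc1ccc(-c2onc3ccc(C(=O)O)cc23)cc1` gives 820 nM, and compound 3 `O=C(O)c1ccc2noc(-c3ccc(NC(=O)C4CCCC4)cc3)c2c1` gives 190 nM, the lowest of the three numbers. The step of a 1.3-fold higher number from compound 1 to compound 2 (0.10 log units; within the scatter) lies within the scatter, while a 3.4-fold lower number from compound 1 to compound 3 (0.53 log units; beyond the scatter) and a 4.3-fold lower number from compound 2 to compound 3 (0.64 log units; beyond the scatter) are modest. Compound 4 `O=C(O)c1ccc2noc(-c3ccc(NC(=O)c4ccncn4)cc3)c2c1` differs from compound 3 by pyrimidin-4-yl in place of cyclopentyl on a carbonyl carbon. Among the measured compounds shown here, only the step from compound 2 to compound 3 bears on this, since it also alters the group on the carbonyl carbon, and no measured compound carries an aromatic group there. Compound 4 is therefore expected to move by a 1.8-fold higher number from compound 3 to compound 4 (0.27 log units; within the scatter), most likely toward a somewhat higher number. Compound 4 is estimated at 350 nM, within 120 nM to 1000 nM.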

Compound 4, half-maximal inhibitory concentration: 720 nM
Compound 4: middle estimate off by 2.1-fold (0.31 log units), on the low side, and the stated range covers the measured number.
By their numbers in this assay, from the lowest: compound 3; then compounds 1, 4 and 2 (each within the scatter of the next).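

In this assay, pyrimidin-4-yl, the only aromatic group shown on the carbonyl carbon, does not hold the level reached with cyclopentyl (a 3.8-fold higher number from compound 3 to compound 4 (0.58 log units; beyond the scatter)). Against isopropyl it shows no separable change (a 1.1-fold lower number from compound 2 to compound 4 (0.06 log units; within the scatter)), and ((pyrimidin-4-yl)carbonyl)amino likewise cannot be separated from (3,5-dichloropyridin-2-yl)oxy (a 1.1-fold higher number from compound 1 to compound 4 (0.04 log units; within the scatter)). No available evidence accounts for the loss from cyclopentyl. As far as these compounds go, it remains open whether phenyl or cyclohexyl on the carbonyl carbon would match cyclopentyl, and so whether the aromatic ring or its ring nitrogens set this result.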